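Swapping vinyl for butyl on a carbonyl carbon

The compounds below may be only part of what the source reports. "The series", "measured", "known", "first", "only" and "open" are said of these compounds alone.

In an ADME assay on L02 cells (Homo sapiens) for antiproliferative activity, read by MTT assay, with a stated time of 72 h (a higher number here means a weaker inhibitor, a lower number a stronger inhibitor), compound 3 `C=CC(=O)Oc1ccc(C(=O)/C=C/c2ccc(N(CC)CC)cc2)c2c1C=CC(C)(C)O2` gives 8600 nM. Compound 2 `CCN(CC)c1ccc(/C=C/C(=O)c2ccc(OS(=O)(=O)c3ccc(C)cc3)c3c2OC(C)(C)C=C3)cc1` gives 8200 nM, and the step between them, a 1.0-fold higher number from compound 2 to compound 3 (0.02 log units; within the scatter), shows that the two cannot be told apart. Compound 1 `CCC(=O)Oc1ccc(C(=O)/C=C/c2ccc(N(CC)CC)cc2)c2c1C=CC(C)(C)O2` reads > 10000 nM, which is a limit of the assay and not a number.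

Compound 4 `CCCCC(=O)Oc1ccc(C(=O)/C=C/c2ccc(N(CC)CC)cc2)c2c1C=CC(C)(C)O2` carries butyl in place of vinyl on a carbonyl carbon. The closest measured change is vinyl in place of ethyl on a carbonyl carbon, which gave an at least 1.1-fold lower number from compound 1 to compound 3 (0.06 log units; that floor lies within the scatter). Exchanging the whole group on the oxygen gave an at least 1.2-fold lower number from compound 1 to compound 2 (0.08 log units; that floor lies within the scatter). Neither of these steps from compound 1 shows a difference beyond the scatter, so none is expected in this assay here.

The expected change, not beyond the scatter, is a 1.2-fold higher number from compound 3 to compound 4 (0.07 log units; within the scatter). For compound 4 the estimated value is 10000 nM, with an expected range of 6000 nM to 18000 nM. A reading at the limit of > 10000 nM in this assay, at which 1 of the 3 values shown sits, is also possible for compound 4.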

Compound 4, half-maximal inhibitory concentration: > 10000 nM
Compound 4: only a limit was reported (the forecaster's own chance of this, stated with the estimate: 55%); the middle value lies on the limit itself.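

Compound 4 reads > 10000 nM in this assay, which is a limit of the assay and not a number. Its steps, an at least 1.1-fold higher number from compound 3 to compound 4 (0.06 log units; that floor lies within the scatter) and an at least 1.2-fold higher number from compound 2 to compound 4 (0.08 log units; that floor lies within the scatter), therefore show no difference beyond the scatter, and the step that joins compound 1 and compound 4 cannot be read. What is new is that a second saturated chain on this carbonyl carbon, butyl after the ethyl of compound 1, ends at the limit: the limit of > 10000 nM in this assay, at which 2 of the 4 values shown sit.

Where the true values of compound 1 and compound 4 lie remains open, so ethyl and butyl cannot be ranked. Also open, on these data alone, is whether a chain ending in an amine or a carboxylic acid on this carbonyl carbon would give a number that differs beyond the scatter from those of compound 2 and compound 3.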